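The source may hold more compounds than are shown below. What is called first, only, known or untested is meant among the compounds shown, and "the series" means these compounds.

In a functional assay on OVCAR-3 cells (Homo sapiens) for antiproliferative activity, read by spectrophotometry, with a stated time of 2 days (a higher number here means a weaker inhibitor of growth, a lower number a stronger inhibitor of growth), the measured compounds are:
Compound 1 `COc1ccc(C(F)(F)F)cc1Nc1ncc(C(F)(F)F)c(N2Cc3cccc(N(C)S(C)(=O)=O)c3C2)n1` gives > 30000 nM (a limit)
Compound 2 `CN(c1cccc2c1CN(c1nc(Nc3ccc(Nc4ccccc4)cc3)ncc1C(F)(F)F)C2)S(C)(=O)=O` gives > 50000 nM (a limit)

Compound 1 therefore stands at > 30000 nM in this assay and this is a limit of the assay, not a number. Compound 2 also reads as a limit at > 50000 nM in the same test. Compound 3 `Cc1cc(C)cc(Nc2ncc(C(F)(F)F)c(N3Cc4cccc(N(C)S(C)(=O)=O)c4C3)n2)c1` has not yet been measured. It carries 3,5-dimethylphenyl in place of 2-methoxy-5-(trifluoromethyl)phenyl on a nitrogen on an aromatic ring. Among the compounds with values here, no measured step shows what this swap does, so no change beyond the usual scatter is expected (a number no higher from compound 1 to compound 3 (the limit leaves the size open)). The estimated value for compound 3 is 30000 nM with an expected range from 8000 nM to 60000 nM in this assay as the read-out.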

Compound 3, concentration for 50% growth inhibition: > 30000 nM
Compound 3: no number, only a limit; the forecaster's own chance of this, stated with the estimate: 70%; the middle value lies on the limit itself.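

No step can be read from compound 1 to compound 3, as each gives only a limit and not a number: the limit of > 30000 nM in this assay, at which 2 of the 3 values shown sit.

Going by these compounds, what putting 3,5-dimethylphenyl in place of 2-methoxy-5-(trifluoromethyl)phenyl does to growth inhibition stays open.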